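The source may hold more compounds than are shown below. What is called first, only, known or untested is meant among the compounds shown, and "the series" means these compounds.

The compounds share the core of compound 1 (`C[C@H]1C(=O)N(C)C=Cc2ccccc21`). In a physicochemical assay for lipophilicity, at pH 7.4 (on this read-out higher numbers stand for higher lipophilicity and lower numbers for lower lipophilicity), compound 1 gives 4.3 and compound 2 (`COc1ccc2c(c1)C=CN(C)C(=O)[C@@H]2C`) gives 4.3, and the step between them reads no change at the digits printed from compound 1 to compound 2 (within the scatter). Compound 3 (`C[C@H]1C(=O)N(C)C=Cc2cc(OC(CO)CO)ccc21`) gives 1.3, the lowest of the three numbers. Two measured steps lead to it: a number 3.00 log units lower from compound 1 to compound 3 (beyond the scatter), and a number 3.00 log units lower from compound 2 to compound 3 (beyond the scatter).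

Compound 4 (`C[C@H]1C(=O)N(C)C=Cc2cc(CN3CCCC3)ccc21`) has (pyrrolidin-1-yl)methyl in place of 2-hydroxy-1-(hydroxymethyl)ethoxy on an aromatic carbon of a six-membered aromatic ring of carbon only: (pyrrolidin-1-yl)methyl in place of 2-hydroxy-1-(hydroxymethyl)ethoxy on an aromatic carbon. The two large steps bear most directly on this change, since both introduce the group that now leaves. They suggest that its removal should move the number upward, towards compound 1, which lacks that group and gives 4.3. Going by the values given here, they cannot settle how far, as no measured compound carries (pyrrolidin-1-yl)methyl, and a full return to that level is not assumed. An upward move beyond the scatter, but smaller than those large steps, is therefore expected: a number 1.20 log units higher from compound 3 to compound 4 (beyond the scatter). For compound 4 the estimate is 2.5, with the expected range running from 1.7 to 3.3.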

Compound 4, distribution coefficient: 1.5
Beside the measured number, compound 4's estimate is 1.00 log units above it; the measured number lies below the stated range.
By their numbers in this assay, from the lowest: compounds 3 and 4 (each within the scatter of the next); then compounds 1 and 2 (each within the scatter of the next).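

At this aromatic carbon, this assay does not separate (pyrrolidin-1-yl)methyl from 2-hydroxy-1-(hydroxymethyl)ethoxy (a number 0.20 log units higher from compound 3 to compound 4 (within the scatter)), even though the first has 0 hydrogen-bond donors against 2 for the second, and it also brings one five-membered non-aromatic ring and a nitrogen in place of oxygen. The low level seen with compound 3 is therefore no longer tied to one group: two quite different groups of 6 heavy atoms each share it, and the large steps from the simpler compounds recur with the new group (a number 2.80 log units lower from compound 1 to compound 4 (beyond the scatter); a number 2.80 log units lower from compound 2 to compound 4 (beyond the scatter)). Nothing measured here accounts for why these two groups match in this assay.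

The compounds shown leave open whether the match depends on the pyrrolidine ring or on the amine nitrogen, a question that an open-chain amine such as dimethylaminomethyl or a morpholin-4-ylmethyl group at this carbon could address. Also open, going by these compounds, is whether a carboxylic acid or a simple hydroxymethyl group at the same place would share that level or fall nearer to compound 1 (4.3).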